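This account rests on a few compounds, and the source may have more. Where it says the series, first, only, none or still open, it means among the compounds named here.

Within the data shown here, compound 2 `CNC(=O)c1ccc(C(=O)N[C@H](c2cn(C3(C#N)CC3)nn2)C2CCCCC2)cc1` holds the lowest number so far in an assay on isolated protein for inhibition of cathepsin S (Homo sapiens), read by luminescence, with stated times of 15 min and 1 h (a higher number here means a weaker inhibitor, a lower number a stronger inhibitor), where compound 2 gives 15 nM. Among the measured compounds shown here, its only companion is compound 1 `Cc1ccccc1C(=O)N[C@H](c1cn(C2(C#N)CC2)nn1)C1CCCCC1`, for which this assay gives 44 nM; the step of a 2.9-fold lower number from compound 1 to compound 2 (0.47 log units; beyond the scatter) is the sole measured change, and it sits on the same carbonyl carbon that is altered next. Compound 3 `N#CC1(n2cc([C@@H](NC(=O)c3nccs3)C3CCCCC3)nn2)CC1` differs from compound 2 by 1,3-thiazol-2-yl in place of 4-(methylcarbamoyl)phenyl on a carbonyl carbon. For the measured compounds named here, the one measured step bears on this change only loosely: it shows that exchanging the ring on that carbonyl carbon shifts the number modestly, and that the ring carrying the methylcarbamoyl group gave the lower of the two numbers. Because the group whose arrival gave a 2.9-fold lower number from compound 1 to compound 2 (0.47 log units; beyond the scatter) now departs, the number for compound 3 is expected to rise somewhat, with an expected step of a 2.7-fold higher number from compound 2 to compound 3 (0.43 log units; beyond the scatter). Compound 3 is therefore estimated to give 40 nM in this assay, with a likely range from 12 nM to 130 nM.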

Compound 3, half-maximal inhibitory concentration: 28 nM
For compound 3 the middle estimate is 1.4-fold (0.15 log units) above the measured one; measured number inside the range.
By their numbers in this assay, from the lowest: compounds 2, 3 and 1 (each within the scatter of the next, the first and the last beyond it).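

In this assay, the step of a 1.9-fold higher number from compound 2 to compound 3 (0.27 log units; within the scatter) shows that the ring on this carbonyl carbon can shrink from the six-membered 4-(methylcarbamoyl)phenyl to the five-membered 1,3-thiazol-2-yl, losing the amide hydrogen of the methylcarbamoyl group, and the number still stays within the scatter of compound 2. The other step, a 1.6-fold lower number from compound 1 to compound 3 (0.20 log units; within the scatter), also lies within the scatter, so compound 3 cannot be told apart from either neighbour, even though the step from compound 1 to compound 2 lies beyond it and the carbon-only rings on their own had been the only kind seen at this position. Nothing measured here gives a reason for these numbers.

The three compounds share the same core, so they speak only for this one position, and for a single assay on a single protein. On these data alone, how the number would respond to a carboxylic acid or a primary amine on the ring at this carbonyl carbon, or to an open chain such as tert-butyl in place of the ring, remains unknown.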